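Where the Bromo Group Sits on the Amide-Bound Ring

The compounds below may be only part of what the source reports. "The series", "measured", "known", "first", "only" and "open" are said of these compounds alone.

Compound 1 `COc1ccc(NC(=O)c2csc(Cc3c(Cl)cccc3Cl)n2)cc1`: in an assay on CHO cells, read by calcium flux (a higher number here means a weaker inhibitor, a lower number a stronger inhibitor), compound 1 gives > 4000 nM, which is a limit of the assay rather than a number.
Compound 2 `O=C(Nc1ccc(Br)cc1)c1csc(Cc2c(Cl)cccc2Cl)n1`: in this assay compound 2 gives 400 nM.
Compound 3 `O=C(Nc1ccccc1Br)c1csc(Cc2c(Cl)cccc2Cl)n1`: in this assay compound 3 gives > 4000 nM, again a limit and not a number.

Compound 3 therefore stands at the top edge of what this assay can report, and its step from compound 1 cannot be sized because of the limit of > 4000 nM in this assay, at which 2 of the 3 values shown sit. Compound 4 `O=C(Nc1cccc(Br)c1)c1csc(Cc2c(Cl)cccc2Cl)n1` has not yet been measured; it differs from compound 3 in one place: 3-bromophenyl in place of 2-bromophenyl on an amide-type nitrogen. Among the compounds with values here, two measured steps bear on this. The step of an at least 10-fold higher number from compound 2 to compound 3 (1.00 log units; beyond the scatter) shows that moving the bromo group from the 4-bromophenyl to the 2-bromophenyl arrangement costs a great deal of potency. The step of an at least 10-fold lower number from compound 1 to compound 2 (1.00 log units; beyond the scatter) shows that a bromo group, at least in the 4-bromophenyl arrangement, is far better than a methoxy group. Within the data shown here, a 3-bromophenyl group is a third arrangement, with no direct precedent here, so the expectation is that compound 4 falls somewhere between compound 2 and compound 3. The step of an at least 2.6-fold lower number from compound 3 to compound 4 (0.42 log units; beyond the scatter) is thus expected to be a gain, though its true size is not readable from a limit. Compound 4 is expected near 1500 nM, within 400 nM to 5000 nM.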

Compound 4, half-maximal inhibitory concentration: > 4000 nM
Compound 4 gave a limit, no number; the forecaster's own chance of this, stated with the estimate: 30%; middle value at least 2.6-fold (0.42 log units) away from the limit.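

The 3-bromophenyl group does not keep the potency of the 4-bromophenyl group in this assay (an at least 10-fold higher number from compound 2 to compound 4 (1.00 log units; beyond the scatter)). The loss seen earlier with the 2-bromophenyl group is therefore not unique to that arrangement: of the three bromophenyl groups on this amide-type nitrogen, only the 4-bromophenyl group of compound 2 gives a readable number, so the presence of a bromo group alone does not secure activity. The steps from compound 3 to compound 4 and from compound 1 to compound 4 cannot be read because the values at both ends are limits and not numbers: (the limit of > 4000 nM in this assay, at which 3 of the 4 values shown sit).

As far as these compounds go, how far compound 3 and compound 4 each lie beyond that limit stays open, so the 2-bromophenyl and 3-bromophenyl groups cannot be placed in order. Also open, from the compounds shown here alone, is whether a chloro or trifluoromethyl group, or a plain phenyl ring with no bromo group at all, could stand in for the 4-bromophenyl group of compound 2, which gives (400 nM).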